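The compounds below may be only part of what the source reports. "The series", "measured", "known", "first", "only" and "open" are said of these compounds alone.

Of the compounds shown here, three built on a shared core have been tested in a functional assay on SW480 cells (Homo sapiens) for cytotoxicity, read by MTT assay, with a stated time of 4 days; a lower number here means a stronger inhibitor, a higher number a weaker inhibitor. Compound 1 `COc1ccc(-c2cn(C[C@H]3c4c(ccc(OS(=O)(=O)c5ccc(C)cc5)c4C)[C@@H]4CC[C@@]5(C)C[C@]43CC5=O)nn2)cc1` gives only a limit in this assay, > 20000 nM. Compound 2 `C=C1C[C@]23C[C@@]1(O)CC[C@@H]2c1cccc(C)c1[C@@H]3Cn1cc(-c2ccc(Cl)cc2)nn1` likewise gives only a limit, > 20000 nM. Compound 3 `Cc1c(O)ccc2c1[C@H](Cn1cc(-c3ccc(C(F)(F)F)cc3)nn1)[C@@]13CC(=O)[C@@](C)(CC[C@@H]21)C3` also gives only a limit, > 20000 nM. Compound 2 therefore stands level with the other two: none of the three reaches a measurable number, and (the limit of > 20000 nM in this assay, at which 3 of the 3 values shown sit). Compound 4 `C=C1C[C@]23C[C@@]1(O)CC[C@@H]2c1cccc(C)c1[C@@H]3Cn1cc(-c2ccc(C(F)(F)F)cc2)nn1` differs from compound 2 in one place: trifluoromethyl in place of chloro on an aromatic carbon, so that 4-chlorophenyl becomes 4-(trifluoromethyl)phenyl. Among the measured compounds shown here, no pair of measured compounds differs in just this way, so no measured step sets the size of the change. Compound 3 carries the same 4-(trifluoromethyl)phenyl on a different core and sits at the limit as well. The expectation is that compound 4 again reports only the limit. The step that this expectation means, a step that the limit leaves unreadable from compound 2 to compound 4, is none beyond the scatter. The estimate for compound 4 is 25000 nM, between 10000 nM and 60000 nM.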

Compound 4, half-maximal inhibitory concentration: > 20000 nM
Compound 4: only a limit was reported; the forecaster's own chance of this, stated with the estimate: 85%; the middle value lies beyond the limit too.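

Compound 2 and compound 4 both give only a limit in this assay, so the size of the step between them cannot be read. The compounds shown leave open how chloro and trifluoromethyl compare, and whether any compound on the shared core gives a measurable number: the limit of > 20000 nM in this assay, at which 4 of the 4 values shown sit.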